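The source may hold more compounds than are shown below. What is called first, only, known or untested is meant among the compounds shown, and "the series" means these compounds.

Measured so far in a functional assay on CHO cells for agonist activity at Alpha-1A adrenergic receptor (Homo sapiens), read by FLIPR and calcium flux; a higher number here means a larger maximal response, a lower number a smaller maximal response:

Compound 1 `CCCS(=O)(=O)Nc1cccc2c1CCC2c1ncc[nH]1`: compound 1 gives 54%.
Compound 2 `CNC(=O)c1cccc2c1CCC2c1ncc[nH]1`: compound 2 gives 59%.

On the numbers shown compound 2 stands at the top of the two, but its only neighbour is compound 1, and the step of a number 5 percentage points higher from compound 1 to compound 2 (within the scatter) is within the scatter, so the two values are not separated. That one step is the whole of the measured record: an exchange of the group on the aromatic carbon of the shared core, methylcarbamoyl in place of (propylsulfonyl)amino, with the maximal response left essentially where it was.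

Compound 3 `c1cc(-c2cn[nH]c2)c2c(c1)C(c1ncc[nH]1)CC2` is not yet measured. It differs from compound 2 by 1H-pyrazol-4-yl in place of methylcarbamoyl on an aromatic carbon. The step from compound 1 to compound 2 is the one that bears on this change, since it also replaces the group at the same aromatic carbon, and it was small. A step of similar size, in no particular direction, is therefore expected, a number 3 percentage points lower from compound 2 to compound 3 (within the scatter). Compound 3 is estimated at 56% in this assay, expected between 36% and 76%.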

Compound 3, largest response reached (Emax), in percent of the reference or control that the assay uses: 84%
The estimate for compound 3 lay 28 percentage points below the measured number; measured number above the stated range.
By their numbers in this assay, from the lowest: compounds 1 and 2 (each within the scatter of the next); then compound 3.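

In this assay, among these compounds, the aromatic carbon of the shared core is not indifferent to its substituent, as the first pair of compounds might have suggested: 1H-pyrazol-4-yl in place of methylcarbamoyl gives a number 25 percentage points higher from compound 2 to compound 3 (beyond the scatter) on the maximal response, and 1H-pyrazol-4-yl in place of (propylsulfonyl)amino gives a number 30 percentage points higher from compound 1 to compound 3 (beyond the scatter) on the same read-out. Of the three groups seen at this carbon, the two without a ring cannot be separated from each other, while the five-membered aromatic ring with 2 hetero atoms stands apart from both, although three compounds are too few to establish a rule about rings. No measured property of these compounds is available to account for the rise.

On these data alone, whether the higher response needs the ring nitrogens of 1H-pyrazol-4-yl or only an aromatic ring at this carbon remains open, and phenyl or pyridinyl at the same place would be the direct comparison. Also open, as far as these compounds go, is whether smaller or charged groups at this carbon, such as an amine or a carboxylic acid, would hold the response, and how potency moves alongside it.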